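From a Benzyl Amine to a Bromophenyl Amine

The source may report more compounds than this note shows. Statements on the series, on what has been measured and on what is new or still open speak of the compounds shown alone.

Of the compounds shown here, three sharing one core have been tested in a functional assay on ECa-109 cells for inhibition, with ECa-109 cell line (Homo sapiens) as the target, read by sulforhodamine B assay; a lower number here means a stronger inhibitor, a higher number a weaker inhibitor. Compound 1 `COc1cccc(NC2=CC(=O)c3c(nc4n3[C@H]3OC[C@@H](O)[C@H]3OC4)C2=O)c1` gives 3340 nM in this assay. Compound 3 `O=C1C(N2CCCC2)=CC(=O)c2c1nc1n2[C@H]2OC[C@@H](O)[C@H]2OC1` reaches only a limit of the assay, > 16000 nM, rather than a number. Going by the values given here, the one measured step of known size is an at least 4.7-fold higher number from compound 1 to compound 3 (0.68 log units; beyond the scatter), in which an arylamino group is replaced by a pyrrolidine. Compound 2 `O=C1C=C(NCc2ccccc2)C(=O)c2c1nc1n2[C@H]2OC[C@@H](O)[C@H]2OC1` likewise reaches only a limit of the assay, > 8000 nM, so no number stands for it among the values shown; it thus cannot be ordered against compound 3.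

Compound 4 `O=C1C=C(Nc2ccc(Br)cc2)C(=O)c2c1nc1n2[C@H]2OC[C@@H](O)[C@H]2OC1` differs from compound 2 in one place: 4-bromophenyl in place of benzyl on an amine nitrogen. Among the compounds with values here, no measured step changes this group in the same way, so the expectation rests on a comparison of the two measured outcomes: compound 1, which carries an arylamino group, gives a number in this assay, whereas compound 2 with its benzylamino group does not. Compound 4 also carries an arylamino group, and is therefore expected to land near compound 1. The step of an at least 2.2-fold lower number from compound 2 to compound 4 (0.35 log units; beyond the scatter) is expected to run toward a lower number. Compound 4 is estimated at 3500 nM, with a range from 1500 nM to 10000 nM.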

Compound 4, half-maximal inhibitory concentration: 2850 nM
The estimate for compound 4 lay 1.2-fold (0.09 log units) above the measured number; the range from low to high includes it.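

In this assay, the change from benzyl to 4-bromophenyl on the amine nitrogen gives an at least 2.8-fold lower number from compound 2 to compound 4 (0.44 log units; beyond the scatter), which shows that this position responds to what sits on the nitrogen even when the heavy-atom count stays the same and each group holds one six-membered aromatic ring. On these data alone, the true size of this step stays unknown because compound 2 reaches a limit of the assay and not a number: the limit of > 8000 nM in this assay, at which 1 of the 4 values shown sits. Going by these compounds alone, with compound 1 at 3340 nM and compound 4 at 2850 nM, two different substituted phenyl groups on this nitrogen now both give a number rather than a limit, which the single arylamino compound could not show.

As far as these compounds go, the change from benzylamino to (4-bromophenyl)amino alters both the link to the ring and the ring's substituent, so the part played by the bromine remains open, and a plain phenyl group on this nitrogen would be needed to separate the two. How a 4-aminophenyl or 4-carboxyphenyl group would read at this position also cannot be told from the values shown.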